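The source may report more compounds than this note shows. Statements on the series, on what has been measured and on what is new or still open speak of the compounds shown alone.

Working notes on the series. The shared core of compound 1 `N#CN1CC(OCc2ccc(-c3ccccc3)cc2)C1` carries a phenyl group on the aromatic carbon, and in an assay on isolated protein for inhibition of N-acylethanolamine-hydrolyzing acid amidase (Homo sapiens), read by fluorescence, with a stated time of 90 min (a lower number here means a stronger inhibitor, a higher number a weaker inhibitor), compound 1 gives 2.8 nM. Among the three numbers measured so far this is the second highest: compound 3 `N#CN1CC(OCc2ccc(Oc3ccccc3)cc2)C1`, with phenoxy in place of phenyl, gives 1.1 nM, a step of a 2.5-fold lower number from compound 1 to compound 3 (0.41 log units; beyond the scatter), while compound 2 `N#CN1CC(OCc2ccc(-c3cccnc3)cc2)C1`, with pyridin-3-yl in place of phenyl, gives 12 nM, a step of a 4.3-fold higher number from compound 1 to compound 2 (0.63 log units; beyond the scatter); between those two the step is an 11-fold lower number from compound 2 to compound 3 (1.04 log units; beyond the scatter). Compound 4 `N#CN1CC[C@@H](OCc2ccc(-c3ccccc3)cc2)C1` is not yet measured. It differs from compound 1 by 1-cyanopyrrolidin-3-yl in place of 1-cyanoazetidin-3-yl on an oxygen on a saturated carbon. Within the data shown here, none of the measured steps touches this part of the molecule; all three vary the aryl group on the aromatic carbon and leave the 1-cyanoazetidin-3-yl in place. Among the measured compounds shown here, there is therefore no measured step that bears on the change, and nothing points in a direction. The expectation for compound 4 in this assay is a step of a 1.4-fold higher number from compound 1 to compound 4 (0.15 log units; within the scatter), not beyond the scatter, with the number estimated at 4 nM within a range from 1 nM to 15 nM.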

Compound 4, half-maximal inhibitory concentration: 26.4 nM
The estimate for compound 4 lay 6.6-fold (0.82 log units) below the measured number; measured number outside the range, above it.
By their numbers in this assay, from the lowest: compound 3; then compound 1; then compound 2; then compound 4.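

The ring on the oxygen is not a silent position: 1-cyanopyrrolidin-3-yl in place of 1-cyanoazetidin-3-yl gives a clear loss in this assay (a 9.4-fold higher number from compound 1 to compound 4 (0.97 log units; beyond the scatter)). Among these compounds, the earlier steps varied only the aryl group on the aromatic carbon, so this is the first sign that the number also depends on the group on the oxygen. The change adds one ring carbon and one defined stereocentre, and the step cannot separate these two features, while no measurement on hand explains the loss.

Open, on these data alone, is whether the opposite configuration of the 1-cyanopyrrolidin-3-yl group would give a similar number, and how a larger 1-cyanopiperidinyl group would compare. Also open, as far as these compounds go, is whether phenoxy in place of phenyl would keep its step on the 1-cyanopyrrolidin-3-yl compound.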